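Trifluoromethyl for nitro on a diazabicyclic aryl amine

The source may hold more compounds than are shown below. What is called first, only, known or untested is meant among the compounds shown, and "the series" means these compounds.

Measured compounds:
compound 1 `Cc1ccc(Nc2cncc(N3CC4CC(C3)N4)c2)cc1`: 1.4 nM
compound 2 `O=[N+]([O-])c1ccc(Nc2ccc(N3CC4CC(C3)N4)cn2)cc1`: 25 nM

Of the compounds shown here, two have been measured in an assay on HEK293 cells for displacement of a labelled ligand from Neuronal acetylcholine receptor; alpha3/beta4 (Homo sapiens); a lower number here means a stronger inhibitor, a higher number a weaker inhibitor. Compound 1 `Cc1ccc(Nc2cncc(N3CC4CC(C3)N4)c2)cc1` gives 1.4 nM in this assay, and compound 2 `O=[N+]([O-])c1ccc(Nc2ccc(N3CC4CC(C3)N4)cn2)cc1` gives 25 nM. Compound 2 thus stands with the higher of the two numbers, and its gap to compound 1 lies beyond the scatter.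

Compound 3 `FC(F)(F)c1ccc(Nc2ccc(N3CC4CC(C3)N4)cn2)cc1` differs from compound 2 in one place: trifluoromethyl in place of nitro on an aromatic carbon. Both groups sit on the same carbon of the same carbon-only ring. Among the compounds with values here, no measured pair shows this exchange, so its effect has to be estimated rather than read off. The expected step from compound 2 to compound 3 is small, a 1.3-fold lower number from compound 2 to compound 3 (0.10 log units; within the scatter), possibly within the scatter, with little reason to prefer one direction. Compound 3 is therefore estimated at 20 nM, within a range from 6 nM to 65 nM.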

Compound 3, inhibition constant: 0.818 nM
The estimate for compound 3 lay 24-fold (1.39 log units) above the measured number; measured number outside the range, below it.
By their numbers in this assay, from the lowest: compounds 3 and 1 (each within the scatter of the next); then compound 2.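

In this assay, the exchange on this aromatic carbon, para to a large group, is far from neutral: trifluoromethyl in place of nitro gives a 31-fold lower number from compound 2 to compound 3 (1.49 log units; beyond the scatter) on an otherwise unchanged structure. Within the data shown here, this is the first view of this position in isolation, since compound 1 and compound 2 differ in more than one place and their gap could not be assigned to any single group. The position therefore responds strongly to the group it carries, although nothing at hand accounts for the size of the step.

Going by these compounds, whether a nitrile, a chlorine atom or a methoxy group on the same carbon would behave like trifluoromethyl or like nitro remains open. So does whether this exchange would have a similar effect on the core of compound 1.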